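The source may hold more compounds than are shown below. What is called first, only, known or untested is meant among the compounds shown, and "the series" means these compounds.

Measured compounds so far:
- compound 1, `O=c1c(Br)c(C(F)(F)F)[nH]c2c(Br)cccc12`, with > 300000 nM
- compound 2, `FC(F)(F)c1nc2c(Br)cccc2c(Cl)c1Br`, with > 300000 nM
- compound 3, `COc1ccc(OC)c(-c2cccc3c(Cl)c(Br)c(C(F)(F)F)nc23)c1`, with > 300000 nM

In an assay for inhibition of ectonucleoside triphosphate diphosphohydrolase 1 (Homo sapiens), read by malachite green, with a stated time of 10 min (on this read-out higher numbers stand for weaker inhibition and lower numbers for stronger inhibition), compound 2 gives > 300000 nM, which is a limit of the assay and not a number. Compound 1 likewise reaches only a limit, > 300000 nM. Compound 3 as well sits at a limit, > 300000 nM. Every value shown therefore rests at the limit of > 300000 nM in this assay, at which 3 of the 3 values shown sit, and compound 2 stands nowhere above or below its companions; it is simply one of the compounds for which no inhibition could be quantified.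

Compound 4, `FC(F)(F)c1nc2c(-c3ccsc3)cccc2c(Cl)c1Br`, has not yet been measured. It differs from compound 2 in one place: thiophen-3-yl in place of bromo on an aromatic carbon. Among the compounds with values here, no pair of measured compounds that differ in a single place exists here, so the size of such a step cannot be read from data. Compound 3 also carries an aromatic ring where compound 2 carries bromo; the value of compound 3, > 300000 nM, is a limit too.

The expectation for compound 4 is therefore that it stays at the limit, an estimated 300000 nM, spanning 100000 nM to 1000000 nM. The expected step of a number no higher from compound 2 to compound 4 (the limit leaves the size open) is none beyond the scatter.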

Compound 4, half-maximal inhibitory concentration: > 300000 nM
Compound 4: no number, only a limit (the forecaster's own chance of this, stated with the estimate: 85%); the middle value lies on the limit itself.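

No step from compound 2 to compound 4 can be read, because both values are limits and not numbers: the limit of > 300000 nM in this assay, at which 4 of the 4 values shown sit.

The compounds shown leave open how much thiophen-3-yl in place of bromo changes inhibition, and which change to the shared core, if any, would give a countable value.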